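Fluoro in Place of Methyl on the Benzyl Amide

The source may report more compounds than this note shows. Statements on the series, on what has been measured and on what is new or still open speak of the compounds shown alone.

Three measured compounds share one core and were read in a functional assay on A2780 cells (Homo sapiens) for cytotoxicity, read by MTT assay, with a stated time of 48 h; on this read-out lower numbers stand for stronger inhibition and higher numbers for weaker inhibition. Compound 1 `CN(C)CCCCN(C)C1=Nc2ccccc2C(CC(=O)NCc2ccccc2)N1c1ccc(-c2ccccc2)cc1` gives in this assay a value of 1650 nM. Compound 2 `CN(C)CCN1CCN(C2=Nc3ccccc3C(CC(=O)NCc3ccccc3)N2c2ccc(-c3ccccc3)cc2)CC1`, which carries a different amine on the carbon with a double bond to nitrogen, gives in this assay a value of 1390 nM, and the step is a 1.2-fold lower number from compound 1 to compound 2 (0.07 log units; within the scatter). Compound 3 `Cc1ccc(CNC(=O)CC2c3ccccc3N=C(N3CCN(CCN(C)C)CC3)N2c2ccc(-c3ccccc3)cc2)cc1` adds a methyl to the benzyl ring and gives in this assay a value of 1600 nM, the step being a 1.2-fold higher number from compound 2 to compound 3 (0.06 log units; within the scatter). Compound 3 thus stands second highest of the three numbers, yet every one of them lies within the scatter of the others, so no order among compounds 1, 2 and 3 can be drawn.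

Compound 4 `CN(C)CCN1CCN(C2=Nc3ccccc3C(CC(=O)NCc3ccc(F)cc3)N2c2ccc(-c3ccccc3)cc2)CC1` differs from compound 3 by fluoro in place of methyl on an aromatic carbon. Among the measured compounds shown here, the step that bears most directly on this change is the one at the same aromatic carbon, a 1.2-fold higher number from compound 2 to compound 3 (0.06 log units; within the scatter), which did not leave the scatter; the only other step, a 1.2-fold lower number from compound 1 to compound 2 (0.07 log units; within the scatter), did not either. Nothing among the three measured compounds points to a step beyond the scatter, so a change of similar size, in no particular direction, is expected as a 1.1-fold lower number from compound 3 to compound 4 (0.03 log units; within the scatter). Compound 4 is therefore estimated at 1500 nM in this assay, within a range from 700 nM to 3200 nM.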

Compound 4, half-maximal inhibitory concentration: 1600 nM
Beside the measured number, compound 4's estimate is 1.1-fold (0.03 log units) below it, and the stated range covers the measured number.
By their numbers in this assay, from the lowest: compounds 2, 3, 4 and 1 (each within the scatter of the next).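

At the aromatic carbon para to a large group, this assay can now be read for three groups on the same background: hydrogen in compound 2, methyl in compound 3 and fluoro in compound 4. Fluoro in place of methyl gives no change at the digits printed from compound 3 to compound 4 (within the scatter), and fluoro in place of hydrogen gives a 1.2-fold higher number from compound 2 to compound 4 (0.06 log units; within the scatter), so, with the earlier methyl step, all three exchanges among these groups stay within the scatter. The earlier compounds showed only that methyl could stand at this carbon without leaving the scatter; the new result extends this to fluoro, and among these three groups the read-out does not separate one from another, though nothing at hand offers a reason for this.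

From the compounds shown here alone, whether a larger or charged group at this carbon, such as a carboxylic acid, a primary amine or a longer alkyl chain, would move the number beyond the scatter remains open. Also open, going by these compounds, is whether fluoro would read the same with the (4-(dimethylamino)butyl)(methyl)amino group of compound 1 on the carbon with a double bond to nitrogen.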